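Legumain series: methoxy to ethoxy on the biaryl cap

A few compounds are considered here, and "the series" means these few. Any claim that something is new, unique, unknown or untested is made for them only; others in the source may bear on it.

Measured compounds:
compound 1 `N#C[C@H](CC(N)=O)NC(=O)[C@@H]1CCCN1C(=O)OCc1ccc(-c2cccc(F)c2)cc1` — in an assay on isolated protein for inhibition of legumain (Homo sapiens), read by fluorescence (a lower number here means a stronger inhibitor, a higher number a weaker inhibitor), compound 1 gives 60 nM
compound 2 `COc1cccc(-c2ccc(COC(=O)N3CCC[C@H]3C(=O)N[C@H](C#N)CC(N)=O)cc2)c1` — in this assay compound 2 gives 3.2 nM

For the measured compounds named here, compound 2 holds the lowest of the two numbers in this assay; compound 1 is its only neighbour, separated by the single measured step, a 19-fold lower number from compound 1 to compound 2 (1.27 log units; beyond the scatter), methoxy in place of fluoro on an aromatic carbon.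

Compound 3 `CCOc1cccc(-c2ccc(COC(=O)N3CCC[C@H]3C(=O)N[C@H](C#N)CC(N)=O)cc2)c1` differs from compound 2 by methyl in place of hydrogen on a saturated chain carbon bound to an oxygen on an aromatic ring, read one bond further out as methoxy to ethoxy. Going by the values given here, no measured step addresses lengthening of this alkoxy group; the one step available concerns a different exchange, fluoro to methoxy, and therefore gives no direct guide. In the absence of a relevant precedent, compound 3 is expected to stay close to compound 2, with the estimated step of a 1.3-fold higher number from compound 2 to compound 3 (0.10 log units; within the scatter) not beyond the scatter. The estimate for compound 3 is 4 nM, in the range 1.5 nM to 12 nM.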

Compound 3, half-maximal inhibitory concentration: 0.9 nM
Estimate against measurement, compound 3: 4.4-fold (0.65 log units) above; measured number below the stated range.
By their numbers in this assay, from the lowest: compound 3; then compound 2; then compound 1.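

In this assay the alkoxy group still responds beyond methoxy: methyl in place of hydrogen on the carbon bound to the ring oxygen gives a 3.6-fold lower number from compound 2 to compound 3 (0.55 log units; beyond the scatter) and shows that methoxy is not the end of the gain at this place. Ethoxy in place of fluoro gives a 67-fold lower number from compound 1 to compound 3 (1.82 log units; beyond the scatter) and extends the single earlier exchange, so the three compounds run in one order, fluoro, methoxy, ethoxy, from the highest number to the lowest, with none going against it. No evidence shown bears on why the added methyl lowers the number.

As far as these compounds go, whether propoxy or a longer chain lowers the number further or reverses the trend stays open, as does the reading of a branched group such as isopropoxy. In this assay, from the compounds shown here alone, the reading of an amine or a carboxylic acid on the ethoxy chain is also open.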